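This account rests on a few compounds, and the source may have more. Where it says the series, first, only, none or still open, it means among the compounds named here.

Measured so far in a functional assay on SW480 cells (Homo sapiens) for cytotoxicity, read by MTT assay, with a stated time of 24 h; a lower number here means a stronger inhibitor, a higher number a weaker inhibitor:

compound 1 `C=CC1=C(C(=O)Nc2ccccc2OC)C(c2ccc(F)cc2)OC1`: compound 1 gives > 100000 nM, which is a limit of the assay and not a number.
compound 2 `C=CC1=C(C(=O)Nc2ccccc2OC)C(c2ccc(Cl)c(Cl)c2)OC1`: compound 2 gives > 100000 nM, again a limit rather than a number.
compound 3 `C=CC1=C(C(=O)NCc2ccccc2)C(c2ccc(F)cc2)OC1`: compound 3 gives > 100000 nM, also a limit and not a number.

All three values sit at the same limit, (the limit of > 100000 nM in this assay, at which 3 of the 3 values shown sit). Compound 2 differs from compound 1 by 3,4-dichlorophenyl in place of 4-fluorophenyl on a saturated ring carbon; the step is a step that the two limits leave unreadable from compound 1 to compound 2. Compound 3 differs from compound 1 in the core by benzyl in place of 2-methoxyphenyl on an amide-type nitrogen; that step is a step that the two limits leave unreadable from compound 1 to compound 3. Neither limit lets the size of either step be read, so the two cores cannot be ranked against each other, nor can the phenyl exchange be given a direction.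

Compound 4 `C=CC1=C(C(=O)NCc2ccccc2)C(c2ccc(Cl)c(Cl)c2)OC1` is not yet measured in this assay. It differs from compound 3 by 3,4-dichlorophenyl in place of 4-fluorophenyl on a saturated ring carbon. The place is described in the same words as for the change from compound 1 to compound 2, so it is the same change, made here on the core of compound 3 instead of the core of compound 1.

For the expected step, compound 4 is estimated to move from compound 3 by a step that the limit leaves unreadable from compound 3 to compound 4, set beside a step that the two limits leave unreadable from compound 1 to compound 2, which is unreadable. Going by the values given here, this rests on the fact that compound 1, compound 2 and compound 3 all sit at the limit of > 100000 nM in this assay, at which 3 of the 3 values shown sit, so there is no measured step on which a different outcome could be based. Compound 4 is therefore expected to give about 200000 nM in this assay, with an estimated range of 50000 nM to 1000000 nM, and most likely only a limit will be reported.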

Compound 4, half-maximal inhibitory concentration: > 100000 nM
Compound 4 ended at the assay's limit; the forecaster's own chance of this, stated with the estimate: 85%; the middle value lies beyond the limit too.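

In this assay compound 4 gives > 100000 nM, which is a limit and not a number. Going by these compounds alone, no step to compound 4 can be read, from either compound 2 or compound 3, since every value shown is the same limit: the limit of > 100000 nM in this assay, at which 4 of the 4 values shown sit. The compounds shown leave open whether the 3,4-dichlorophenyl or benzyl exchange has any effect on cytotoxicity, and in which direction.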